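Fluoro for Methyl on the Triazole Aryl Ring

The compounds below may be only part of what the source reports. "The series", "measured", "known", "first", "only" and "open" are said of these compounds alone.

Compound 1 `C=C1C[C@]23C[C@@]1(O)CC[C@H]2c1ccc(OS(=O)(=O)c2ccc(C)cc2)c(C)c1[C@@H]3Cn1cc(-c2ccc(Br)cc2)nn1` carries a bromo group on the phenyl ring attached to the triazole. In a functional assay on SW480 cells (Homo sapiens) for cytotoxicity, read by MTT assay, with a stated time of 4 days (on this read-out higher numbers stand for weaker inhibition and lower numbers for stronger inhibition), compound 1 reaches only the limit of the assay, > 20000 nM. Compound 2 `C=C1C[C@]23C[C@@]1(O)CC[C@H]2c1ccc(OS(=O)(=O)c2ccc(C)cc2)c(C)c1[C@@H]3Cn1cc(-c2ccc(C)cc2)nn1` differs from it by a methyl in place of bromo on an aromatic carbon. In this assay compound 2 likewise sits at a limit, > 20000 nM. The step that the two limits leave unreadable from compound 1 to compound 2 therefore cannot be read; both values rest at the limit of > 20000 nM in this assay, at which 2 of the 2 values shown sit. Compound 3 `C=C1C[C@]23C[C@@]1(O)CC[C@H]2c1ccc(OS(=O)(=O)c2ccc(C)cc2)c(C)c1[C@@H]3Cn1cc(-c2ccc(F)cc2)nn1` is the next member of the series: fluoro in place of methyl on an aromatic carbon. For the measured compounds named here, the only measured step, from compound 1 to compound 2, bears on this change yet gives no size, so no shift beyond the scatter is expected, and compound 3 is expected to remain at the limit. The estimate for compound 3 in this assay is 30000 nM, between 15000 nM and 80000 nM. The expected step that the limit leaves unreadable from compound 2 to compound 3 is thus essentially none.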

Compound 3, half-maximal inhibitory concentration: > 20000 nM
Compound 3: no number, only a limit; the forecaster's own chance of this, stated with the estimate: 85%; the middle value is on the limit's open side.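

In this assay compound 3 gives > 20000 nM, which is a limit and not a number. For the compounds shown here, no step among compound 1, compound 2 and compound 3 can be read: the limit of > 20000 nM in this assay, at which 3 of the 3 values shown sit. The compounds shown leave open whether the bromo, methyl and fluoro groups differ at all on this read-out.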